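This account rests on a few compounds, and the source may have more. Where it says the series, first, only, none or still open, it means among the compounds named here.

Measured so far:
- compound 1 `COc1ccc(/C=C2\CCC/C(=C\c3ccc([N+](=O)[O-])cc3)C2=O)cc1`: 435000 nM
- compound 2 `COc1ccc(/C=C2\CCC/C(=C\c3c(Cl)cccc3Cl)C2=O)cc1`: 232000 nM

In an ADME assay on Vero cells (Chlorocebus sabaeus) for inhibition (on this read-out higher numbers stand for lower toxicity in this test and lower numbers for higher toxicity in this test), compound 2 gives 232000 nM, which stands within the scatter of compound 1 at 435000 nM, so the two cannot be ranked. Compound 3 `COc1ccc(/C=C2\CCC/C(=C\c3ccc(F)cc3)C2=O)cc1` has not been measured. Its difference from compound 2 is 4-fluorophenyl in place of 2,6-dichlorophenyl on a double-bonded chain carbon bound to a double-bonded ring carbon. For the measured compounds named here, no single-place step has been measured, so the expectation rests only on the two values in hand, which lie close together. The expected change is a 1.3-fold higher number from compound 2 to compound 3 (0.11 log units; within the scatter), with no step beyond the scatter anticipated. For compound 3 the estimated value in this assay is 300000 nM, with an expected range of 140000 nM to 620000 nM.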

Compound 3, half-maximal cytotoxic concentration: 378000 nM
Beside the measured number, compound 3's estimate is 1.3-fold (0.10 log units) below it; low and high end bracket the measured number.
By their numbers in this assay, from the lowest: compounds 2, 3 and 1 (each within the scatter of the next).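

In this assay the place on a double-bonded chain carbon bound to a double-bonded ring carbon now has readable steps: 4-fluorophenyl in place of 2,6-dichlorophenyl gives a 1.6-fold higher number from compound 2 to compound 3 (0.21 log units; within the scatter) and fluoro in place of nitro on an aromatic carbon gives a 1.2-fold lower number from compound 1 to compound 3 (0.06 log units; within the scatter) with the rest of the structure unchanged. Neither step leaves the scatter, so these three aryl groups are not separated by this read-out. Nothing on hand offers an explanation for this result.

Open, going by these compounds, is whether an amine or a carboxylic acid on this aryl ring, or a longer chain in its place, would give a step beyond the scatter. Also open, on these data alone, is whether changes elsewhere on the shared core would read any differently in this assay than the changes at this place.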